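Iminosugar Ether Side Chains and Cytotoxicity in Bovine Kidney Cells

The source may report more compounds than this note shows. Statements on the series, on what has been measured and on what is new or still open speak of the compounds shown alone.

Among the compounds with values here, compound 1 `CCC1CCCCC1OCCCCCCN1C[C@H](O)[C@@H](O)[C@H](O)[C@H]1CO` is the less toxic of the two compounds measured so far. In an ADME assay on MDBK cells (Bos taurus) for cytotoxicity, read by MTT assay (on this read-out higher numbers stand for lower toxicity in this test and lower numbers for higher toxicity in this test), compound 1 gives 450000 nM, the highest of the two numbers, while compound 2 `OC[C@@H]1[C@@H](O)[C@H](O)[C@@H](O)CN1CCCCCCOC1CCCCC1C1CCCCC1` gives 200000 nM. Within the data shown here, the only measured step, a 2.3-fold lower number from compound 1 to compound 2 (0.35 log units; beyond the scatter), is modest, and it comes from a cyclohexyl in place of ethyl on a saturated ring carbon.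

Compound 3 `COc1ccccc1OCCCCCCN1C[C@H](O)[C@@H](O)[C@H](O)[C@H]1CO` differs from compound 1 in another way: a group of 8 heavy atoms (7 carbon, 1 oxygen; one six-membered aromatic ring of carbon only) in place of a group of 8 heavy atoms (8 carbon; one six-membered non-aromatic ring of carbon only), on an oxygen on a saturated carbon. Among the measured compounds shown here, no measured step concerns an aromatic group entering in place of a saturated ring, so the step from compound 1 to compound 2 bears on the new change only loosely: it shows that altering the group on the ether oxygen moved the number by a modest amount. The groups leaving and entering here are of the same count of heavy atoms, so a step no larger than that one is expected, in either direction or none beyond the scatter. For compound 3 the expected step is a 1.1-fold higher number from compound 1 to compound 3 (0.05 log units; within the scatter), and its value is estimated at 500000 nM, with a range from 200000 nM to 1200000 nM.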

Compound 3, half-maximal cytotoxic concentration: > 500000 nM
Compound 3: only a limit was reported; the forecaster's own chance of this, stated with the estimate: 20%; the middle value lies on the limit itself.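

In this assay the reading for compound 3 is a limit and not a number, so this result sets only a floor for the change and not its size: the limit of > 500000 nM in this assay, at which 1 of the 3 values shown sits. The step is an at least 1.1-fold higher number from compound 1 to compound 3 (0.04 log units; that floor lies within the scatter), which means that 2-methoxyphenyl on the oxygen on a saturated carbon, with its six-membered aromatic ring of carbon, does not bring the number down from that of the saturated group it replaces. The earlier compounds shown here showed only a change between saturated groups at this position, a 2.3-fold lower number from compound 1 to compound 2 (0.35 log units; beyond the scatter), which moved the number down, whereas this first aromatic group gives no such fall, though whether it truly raises the number beyond the scatter cannot be told from a floor.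

On these data alone, how far the true number of compound 3 lies past its limit remains open, and so does the part played by the methoxy group, which a plain phenyl group would help to separate from that of the aromatic ring. Also open, as far as these compounds go, is whether an amine or a carboxylic acid on the aromatic ring, or a longer chain, would leave the number as high in this test.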